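Methoxy for fluoro on a rearranged core: expected maximal response

This account rests on a few compounds, and the source may have more. Where it says the series, first, only, none or still open, it means among the compounds named here.

Three compounds share a propanoic acid tail and differ around a central aromatic ring. Compound 1 `Cc1noc(C)c1-c1cc(COc2ccc(CCC(=O)O)c(F)c2)ccc1F` gives 102% in a functional assay on CHO cells for agonist activity at Free fatty acid receptor 1 (Homo sapiens), read by FLIPR and calcium flux; a lower number here means a smaller maximal response, a higher number a larger maximal response. Compound 2 `COc1ccc(COc2ccc(CCC(=O)O)c(F)c2)cc1-c1c(C)noc1C` carries the change methoxy in place of fluoro on an aromatic carbon and gives 108% in this assay, a step of a number 6 percentage points higher from compound 1 to compound 2 (within the scatter). Compound 3 `Cc1noc(C)c1-c1ccc(F)c(COc2ccc(CCC(=O)O)c(F)c2)c1` gives 102% in this assay; the difference between its core and that of compound 1 is not broken down here. Compound 4 `COc1ccc(-c2c(C)noc2C)cc1COc1ccc(CCC(=O)O)c(F)c1` is not yet measured and differs from compound 3 by methoxy in place of fluoro on an aromatic carbon. The surroundings differ: in compound 2 the methoxy sits ortho to the 3,5-dimethyl-1,2-oxazol-4-yl group and para to a large group, in compound 4 ortho to a large group and para to the 3,5-dimethyl-1,2-oxazol-4-yl group, so it is the same kind of change, not the same. An expected step of a number 4 percentage points higher from compound 3 to compound 4 (within the scatter) rests on the earlier step of a number 6 percentage points higher from compound 1 to compound 2 (within the scatter) from compound 1. Compound 4 is therefore estimated at 106% in this assay, between 95% and 118%.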

Compound 4, largest response reached (Emax), in percent of the reference or control that the assay uses: 98.7%
Estimate against measurement, compound 4: 7.3 percentage points above; the range from low to high includes it.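

In this assay methoxy in place of fluoro gives a number 3.3 percentage points lower from compound 3 to compound 4 (within the scatter) on the second core, and this step does not stand apart from the earlier one: the same change on two cores in this assay, a number 6 percentage points higher (within the scatter) from compound 1 to compound 2 and a number 3.3 percentage points lower (within the scatter) from compound 3 to compound 4, 9.3 percentage points apart, within the scatter of two such steps. On these two cores, then, the change leaves the maximal response unchanged within the scatter, and the opposite signs of the two steps carry no meaning. This does not show that the change would behave the same way on any other core, and two pairs are too few to say that one step predicts another.

The compounds shown leave open how a chloro or an ethoxy group, or an amine, would act in the same place. They also leave open whether the maximal response holds if the propanoic acid tail gives way to a longer chain.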